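This account rests on a few compounds, and the source may have more. Where it says the series, first, only, none or still open, it means among the compounds named here.

Compound 1 `COc1ccc(CS(=O)(=O)/C=C/c2ccc(F)cc2)cc1` gives 2500 nM in a functional assay on H157 cells (Homo sapiens) for antiproliferative activity, read by trypan blue exclusion; a higher number here means a weaker inhibitor, a lower number a stronger inhibitor; compound 2 `COc1ccc(CS(=O)(=O)/C=C/c2ccc(Cl)cc2)cc1` gives 3500 nM in this assay.

Compound 1 holds the lowest of the two numbers in this assay, with compound 2 as its nearest neighbour at a 1.4-fold higher number from compound 1 to compound 2 (0.15 log units; within the scatter). Compound 3 `COc1ccc(CS(=O)(=O)/C=C/c2ccc(F)cc2Cl)cc1` differs from compound 1 by chloro in place of hydrogen on an aromatic carbon. For the measured compounds named here, no measured step adds a chloro group in place of hydrogen; the only step known, a swap of chloro for fluoro on an aromatic carbon, stayed within the scatter at a 1.4-fold higher number from compound 1 to compound 2 (0.15 log units; within the scatter). The step from compound 1 to compound 3 is therefore expected to be no change at the digits printed from compound 1 to compound 3 (within the scatter), nothing beyond the scatter. Compound 3 is estimated at 2500 nM, within a range of 1000 nM to 6500 nM.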

Compound 3, half-maximal inhibitory concentration: 2500 nM
For compound 3 middle estimate and measured number coincide at the digits printed; the measured number falls inside the stated range.
By their numbers in this assay, from the lowest: compounds 1, 3 and 2 (each within the scatter of the next).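

In this assay, chloro in place of hydrogen on an aromatic carbon, ortho to a large group and meta to a fluoro group, gives no change at the digits printed from compound 1 to compound 3 (within the scatter) and so stays within the scatter. The earlier swap of chloro for fluoro concerned a group already present, whereas this step shows that the core of compound 1 can take an added chlorine at a new position with no change beyond the scatter. No evidence given here accounts for this result.

Going by these compounds, whether an amine or a nitrile at this position would leave the number as little changed remains open. So does whether a larger group, such as a phenyl ring, would do the same.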